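From methoxycarbonyl to ethoxycarbonyl in the series

The source may report more compounds than this note shows. Statements on the series, on what has been measured and on what is new or still open speak of the compounds shown alone.

In a physicochemical assay, read by HPLC, in phosphate buffer, with a stated time of 2 h, at pH 7.4 (a lower number here means that less of the compound is left, a higher number that more of the compound is left), compound 1 (`C[C@@H]1CN(C(=O)c2nc(Nc3cc(C4CC4)[nH]n3)c3cc(Cl)ccc3n2)CCN1C(=O)OCc1ccccc1`) gives 97.7% with phenyl on a saturated chain carbon bound to an oxygen next to a carbonyl group. Compound 2 (`CCCCCOC(=O)N1CCN(C(=O)c2nc(Nc3cc(C4CC4)[nH]n3)c3cc(Cl)ccc3n2)C[C@H]1C`) gives 99.8% with butyl at that place, and compound 3 (`COC(=O)N1CCN(C(=O)c2nc(Nc3cc(C4CC4)[nH]n3)c3cc(Cl)ccc3n2)C[C@H]1C`) gives 100% with hydrogen there. Compound 3 thus stands level with the other two, all three numbers lying within the scatter of one another.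

The step to compound 4 (`CCOC(=O)N1CCN(C(=O)c2nc(Nc3cc(C4CC4)[nH]n3)c3cc(Cl)ccc3n2)C[C@H]1C`) puts methyl in place of hydrogen on that same carbon (methyl in place of hydrogen on a saturated chain carbon bound to an oxygen next to a carbonyl group) and so turns methoxycarbonyl into ethoxycarbonyl. The measured steps at this place bear directly on it: a number 0.2 percentage points higher from compound 2 to compound 3 (within the scatter) for hydrogen in place of butyl, a number 2.3 percentage points higher from compound 1 to compound 3 (within the scatter) for hydrogen in place of phenyl and a number 2.1 percentage points higher from compound 1 to compound 2 (within the scatter) for butyl in place of phenyl, each within the scatter. With hydrogen, butyl and phenyl all giving such steps, no step beyond the scatter is expected for methyl in this assay at this place. The estimate amounts to a number 1 percentage points lower from compound 3 to compound 4 (within the scatter) and is expected to stay within the scatter. For compound 4 the estimated value is 99% with an expected range from 93% to 100% on this read-out.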

Compound 4, percent of the compound remaining: 97.7%
The estimate for compound 4 lay 1.3 percentage points above the measured number; the range from low to high includes it.
By their numbers in this assay, from the lowest: compounds 1, 4, 2 and 3 (each within the scatter of the next).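

With methyl on the saturated chain carbon bound to an oxygen next to a carbonyl group, the read-out shows a number 2.3 percentage points lower from compound 3 to compound 4 (within the scatter) in this assay and so extends the flat picture seen with hydrogen, butyl and phenyl to the change from methoxycarbonyl to ethoxycarbonyl. The comparisons with the two larger groups give a number 2.1 percentage points lower from compound 2 to compound 4 (within the scatter) and no change at the digits printed from compound 1 to compound 4 (within the scatter) for the phenyl compound, so compounds 1, 2, 3 and 4 all lie within the scatter of one another, and across these four the percent remaining does not separate the groups at this carbon. Nothing available explains this flat read-out at this place.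

Whether the picture holds for a group carrying an amine or a carboxylic acid on this carbon remains open, since the four groups shown are hydrogen, methyl, butyl and phenyl. Also open, from the compounds shown here alone, is what happens when the methoxycarbonyl group gives way to an acetyl group. Every compound shown keeps the same oxygen and carbonyl arrangement at this place.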